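Working notes on cell toxicity in a small series

The source may hold more compounds than are shown below. What is called first, only, known or untested is meant among the compounds shown, and "the series" means these compounds.

Measured compounds:
- compound 1 `Fc1ccc(-c2nn3c(NC4CC4)cc(Cl)cc3c2-c2ccnc(NC3CCCC3)n2)cc1`: in an ADME assay on Vero cells (Chlorocebus sabaeus) for cytotoxicity (on this read-out higher numbers stand for lower toxicity in this test and lower numbers for higher toxicity in this test), compound 1 gives > 40000 nM, which is a limit of the test and not a number.
- compound 2 `CC(C)Nc1cc(Cl)cc2c(-c3ccnc(NC4CCCC4)n3)c(-c3ccc(F)cc3)nn12`: in this assay compound 2 gives > 40000 nM, again a limit.
- compound 3 `Fc1ccc(-c2nn3c(N4CCCCC4)cc(Cl)cc3c2-c2ccnc(NC3CCCC3)n2)cc1`: in this assay compound 3 gives > 40000 nM, again a limit.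

Among the measured compounds shown here, compound 1 therefore stands only at a limit in this assay, and the two further values shown are limits as well, so no compound of the three can be placed above or below another on this read-out. The three measured steps, a step that the two limits leave unreadable from compound 1 to compound 2, a step that the two limits leave unreadable from compound 1 to compound 3 and a step that the two limits leave unreadable from compound 2 to compound 3, all concern the amine attached to the shared core, and all three are unreadable because of the limit of > 40000 nM in this assay, at which 3 of the 3 values shown sit.

Compound 4 `COc1ccc(-c2nn3c(NC4CC4)cc(Cl)cc3c2-c2ccnc(NC3CCCC3)n2)cc1` differs from compound 1 by methoxy in place of fluoro on an aromatic carbon. For the measured compounds named here, none of the measured steps touches this part of the molecule, so they bear on the change only in the broad sense that every alteration measured so far has left the read-out at the limit. On that basis compound 4 is expected to give an estimated 50000 nM, within 25000 nM to 120000 nM. The corresponding step that the limit leaves unreadable from compound 1 to compound 4 is expected to lie within scatter, with the result most likely reported once more as a limit only.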

Compound 4, half-maximal cytotoxic concentration: > 40000 nM
Compound 4: a limit, no number (the forecaster's own chance of this, stated with the estimate: 80%); the middle value lies beyond the limit too.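

No new step can be read between compound 1 and compound 4 in this assay, because both stand at a limit and not at a number: the limit of > 40000 nM in this assay, at which 4 of the 4 values shown sit.

The compounds shown leave open whether the change from 4-fluorophenyl to 4-methoxyphenyl, or any of the amine changes, alters the read-out, and how the four compounds rank against one another.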